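Fluoro to Iodo on a Shared Urea Core

A few compounds are considered here, and "the series" means these few. Any claim that something is new, unique, unknown or untested is made for them only; others in the source may bear on it.

Of the compounds shown here, three with one shared core have been tested in an ADME assay on the whole organism with Oryza sativa as the target, tested at 0.1 uM; a higher number here means a weaker effect of the compound at the concentration tested, a lower number a stronger effect. Compound 1 `CCCCc1ccc(NC(=O)N[C@H](C)c2ccccc2)cc1` gives 100%. Compound 2 `CCCCCCc1ccc(NC(=O)N[C@H](C)c2ccccc2)cc1` gives 100% in this assay. Compound 3 `C[C@@H](NC(=O)Nc1ccc(F)cc1)c1ccccc1` gives 98% in this assay, the lowest of the three numbers, although its gaps to the others, a number 2 percentage points lower from compound 1 to compound 3 (within the scatter) and a number 2 percentage points lower from compound 2 to compound 3 (within the scatter), lie within the scatter, as does no change at the digits printed from compound 1 to compound 2 (within the scatter). Compound 4 `C[C@@H](NC(=O)Nc1ccc(I)cc1)c1ccccc1` is the next step: iodo in place of fluoro on an aromatic carbon. Among the compounds with values here, no measured step replaces fluoro by anything, so none bears directly on this change; what the three measured steps do show is that every change so far left the read-out unmoved. The expected step is therefore a number 1 percentage points higher from compound 3 to compound 4 (within the scatter), none beyond the scatter. Compound 4 is estimated at 99%, with a range from 90% to 100%.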

Compound 4, a percentage reported as activity, at one concentration (the size of the read-out at that concentration, not a potency): 100%
Compound 4: the middle estimate sits 1 percentage points below what was measured; measured number inside the range.
By their numbers in this assay, from the lowest: compounds 3, 1, 2 and 4 (each within the scatter of the next).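

Iodo in place of fluoro, the only swap of one halogen for another among these compounds, gives a number 2 percentage points higher from compound 3 to compound 4 (within the scatter) in this assay. Iodo in place of the chains reads the same, with no change at the digits printed from compound 2 to compound 4 (within the scatter) and no change at the digits printed from compound 1 to compound 4 (within the scatter), so at this position a single iodine and a butyl or hexyl chain cannot be told apart. No supporting data bear on this flat read-out. On these data alone, whether any group here can move the number stays open, for instance an amine or a carboxylic acid in the same place. Changes elsewhere on the shared core also remain untested by these compounds.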